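Piperazine amide variation on a shared core

The source may hold more compounds than are shown below. What is called first, only, known or untested is meant among the compounds shown, and "the series" means these compounds.

Measured so far in a functional assay on CHO cells for antagonist activity at adenosine receptor A2b (Homo sapiens); a lower number here means a stronger inhibitor, a higher number a weaker inhibitor:
Compound 1, `Nc1nc(N2CCCC2)nc2nc(-c3ccco3)nn12`, gives > 30000 nM, which is a limit of the assay.
Compound 2, `CCCCC(=O)N1CCN(c2nc(N)n3nc(-c4ccco4)nc3n2)CC1`, gives > 100000 nM, a limit of the assay.
Compound 3, `Nc1nc(N2CCN(C(=O)C(Cl)Cl)CC2)nc2nc(-c3ccco3)nn12`, gives > 100000 nM, again a limit of the assay.

Compound 3 thus stands only at a limit in this assay, and the two other values shown are limits as well; two of the three sit at the limit of > 100000 nM in this assay, at which 2 of the 3 values shown sit, one at the limit of > 30000 nM in this assay, at which 1 of the 3 values shown sits. Going by the values given here, no compound in the set has a numerical value.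

Compound 4, `CC(C)(C)CC(=O)N1CCN(c2nc(N)n3nc(-c4ccco4)nc3n2)CC1`, differs from compound 3 as follows: neopentyl in place of dichloromethyl on a carbonyl carbon. Among the compounds with values here, the only measured step that touches the same place is a step that the two limits leave unreadable from compound 2 to compound 3. Both ends of that step are limits, so its size cannot be read. The butyl amide of compound 2 and the dichloromethyl amide of compound 3 therefore give no direction for a neopentyl amide.

Compound 4 is expected to behave like the other two amides and to remain at or beyond the limit in this assay, so the step of a number no higher from compound 3 to compound 4 (the limit leaves the size open) is estimated as none readable. The estimate for compound 4 is 100000 nM, with a range from 30000 nM to 300000 nM.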

Compound 4, half-maximal inhibitory concentration: > 100000 nM
Compound 4: only a limit was reported (the forecaster's own chance of this, stated with the estimate: 80%); the middle value lies on the limit itself.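

In this assay compound 4 gives > 100000 nM as a limit of the assay. The values of compound 2, compound 3 and compound 4 are all limits, and no step among these compounds can be read. Left open is whether in this assay any amide group on the shared core gives a numerical value rather than a limit.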